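The compounds below may be only part of what the source reports. "The series", "measured", "known", "first", "only" and "open" are said of these compounds alone.

Compound 2 `O=S(=O)(Nc1ccc2oc(-c3ccccc3)nc2c1)c1cccc(F)c1` and compound 1 `Cc1ccc(S(=O)(=O)Nc2ccc(-c3nc4ccccc4o3)cc2)cc1` have both been tested in an ADME assay on HEK293 cells (Homo sapiens) for cytotoxicity, read by resazurin assay, with a stated time of 48 h; on this read-out lower numbers stand for higher toxicity in this test and higher numbers for lower toxicity in this test. In this assay compound 2 gives 68000 nM, and compound 1 gives 88000 nM; these two numbers lie within the usual scatter of each other, so they cannot be told apart. Compound 3 `O=S(=O)(Nc1ccc2oc(-c3ccccc3)nc2c1)c1ccc(Cl)s1` has not yet been measured. It differs from compound 2 in one place: 5-chlorothiophen-2-yl in place of 3-fluorophenyl on a sulfonyl sulfur. Among the compounds with values here, no measured pair shows what such a swap does here, so no change beyond the scatter is expected. The expected step is therefore small, no change at the digits printed from compound 2 to compound 3 (within the scatter). For compound 3 the estimate is 68000 nM, with a range from 30000 nM to 150000 nM.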

Compound 3, half-maximal cytotoxic concentration: > 100000 nM
Compound 3 was reported as a limit; the forecaster's own chance of this, stated with the estimate: 10%; middle value at least 1.4-fold (0.16 log units) away from the limit.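

The sulfonyl sulfur now has its first measured swap: in this assay, 5-chlorothiophen-2-yl in place of 3-fluorophenyl gives an at least 1.4-fold higher number from compound 2 to compound 3 (0.16 log units; that floor lies within the scatter), so the step is known only as a floor. The reading for compound 3 is a limit and not a number: the limit of > 100000 nM in this assay, at which 1 of the 3 values shown sits. Even so, this swap shows no sign of higher toxicity in this test, and a ring with a sulfur and a chlorine is tolerated here.

As far as these compounds go, it remains open whether an amine or a carboxylic acid at this sulfonyl sulfur would give a lower number in this assay.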